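The source may report more compounds than this note shows. Statements on the series, on what has been measured and on what is new or still open speak of the compounds shown alone.

Measured compounds in a functional assay on VCaP cells (Homo sapiens) for antiproliferative activity, read by propidium iodide staining, with a stated time of 96 h; a higher number here means a weaker inhibitor, a lower number a stronger inhibitor:

Compound 1, `CC(O)(COc1ccc(S(F)(F)(F)(F)F)cc1)C(=O)Nc1ccc(S(F)(F)(F)(F)F)cc1`, gives 9300 nM.
Compound 2, `CC(O)(COc1cccc(S(F)(F)(F)(F)F)c1)C(=O)Nc1ccc(S(F)(F)(F)(F)F)cc1`, gives 11400 nM.
Compound 3, `CC(O)(COc1cccc(C(F)(F)F)c1)C(=O)Nc1ccc(S(F)(F)(F)(F)F)cc1`, gives 24700 nM.

The unmeasured compound 4 is `CC(O)(COc1ccc(S(F)(F)(F)(F)F)cc1)C(=O)Nc1ccc(C(F)(F)F)cc1`. Compound 1 has the lowest number of the three measured; the values of compound 1 and compound 2 lie within the scatter of each other, so no order between them is claimed. Compound 1 and compound 2 share the same atoms joined differently; the difference between the two cores is not broken down here.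

One change has been measured once: a group of 4 heavy atoms (1 carbon, 3 fluorine; no ring) in place of a group of 6 heavy atoms (5 fluorine, 1 sulfur; no ring), on an aromatic carbon, giving a 2.2-fold higher number from compound 2 to compound 3 (0.34 log units; beyond the scatter). The change to compound 4 is a group of 4 heavy atoms (1 carbon, 3 fluorine; no ring) in place of a group of 6 heavy atoms (5 fluorine, 1 sulfur; no ring), on an aromatic carbon. It is the same kind of change, but the place differs: in compound 3 the new group is meta to a large group, in compound 4 it is para to a large group.

Among the measured compounds shown here, for compound 4 a step of about a 2.2-fold higher number from compound 1 to compound 4 (0.33 log units; beyond the scatter) is expected, resting on the one measured step of a 2.2-fold higher number from compound 2 to compound 3 (0.34 log units; beyond the scatter), with wider uncertainty since the place is not the same. Compound 4 is estimated at 20000 nM in this assay, between 8000 nM and 50000 nM.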

Compound 4, half-maximal inhibitory concentration: 14700 nM
Compound 4: the middle estimate sits 1.4-fold (0.13 log units) above what was measured; the range from low to high includes it.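

In this assay, trifluoromethyl in place of the group of 6 heavy atoms (5 fluorine, 1 sulfur), para to a large group, gives a 1.6-fold higher number from compound 1 to compound 4 (0.20 log units; within the scatter), and this step does not differ from the earlier one: the same change on two cores in this assay, a 2.2-fold higher number (0.34 log units; beyond the scatter) from compound 2 to compound 3 and a 1.6-fold higher number (0.20 log units; within the scatter) from compound 1 to compound 4, 1.4-fold (0.14 log units) apart, within the scatter of two such steps. On these two pairs, the change therefore carries from one core to the other without a measurable difference. This does not fix a general size for the change: it rests on two pairs in one assay, the two steps do not sit at the same place, and the step on compound 1 alone does not lie beyond the scatter.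

The compounds shown leave open how a nitrile, a chlorine or a longer chain would compare with these two groups at the same places. Also open, going by these compounds, is whether the step would hold on cores that carry an amine or a carboxylic acid.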